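This account rests on a few compounds, and the source may have more. Where it says the series, first, only, none or still open, it means among the compounds named here.

Compound 2 `C(=C1\CCCN=C1c1cccnc1)\c1ccccc1` gives 850 nM in an assay on membranes from brain for displacement of a labelled ligand from Neuronal acetylcholine receptor; alpha4/beta2 (Rattus norvegicus), with a stated time of 3 h (a lower number here means a stronger inhibitor, a higher number a weaker inhibitor), the lower of the two numbers recorded, though within the scatter of compound 1 `CC(C)(C)C(=O)Oc1ccccc1/C=C1\CCCN=C1c1cccnc1`, which in this assay gives 1440 nM. Among the compounds with values here, the one measured step, a 1.7-fold lower number from compound 1 to compound 2 (0.23 log units; within the scatter), concerns a different change and stays within the scatter. Compound 3 `CSc1ccc(/C=C2\CCCN=C2c2cccnc2)cc1` carries methylsulfanyl in place of hydrogen on an aromatic carbon. Within the data shown here, no measured step speaks to this change directly, so compound 3 is expected to show a 1.1-fold lower number from compound 2 to compound 3 (0.03 log units; within the scatter), with no clear direction. Compound 3 is therefore estimated at 800 nM, in a range from 250 nM to 2500 nM.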

Compound 3, inhibition constant: 900 nM
Estimate against measurement, compound 3: 1.1-fold (0.05 log units) below, within the range that was stated.
By their numbers in this assay, from the lowest: compounds 2, 3 and 1 (each within the scatter of the next).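

Placing methylsulfanyl on an aromatic carbon, para to a large group, gives a 1.1-fold higher number from compound 2 to compound 3 (0.02 log units; within the scatter) in this assay. This place therefore accepts a group of two heavy atoms, one of them sulfur, with no change beyond the scatter, something the earlier step, which concerned a different group, could not show. Nothing measured here accounts for this result. Going by these compounds, whether an amine or a carboxylic acid at this place would also stay within the scatter of compound 2 remains open, as does the effect of methylsulfanyl on another carbon of the ring.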